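This account rests on a few compounds, and the source may have more. Where it says the series, first, only, none or still open, it means among the compounds named here.

Compound 3 `CCCCCCCCCCc1ccc(-c2noc([C@@H]3CCCN3)n2)cc1` gives 21% in an assay on HeLa cells for inhibition of sphingosine-1-phosphate transporter SPNS2 (Mus musculus), read by LC-MS, tested at 2 uM (on this read-out lower numbers stand for less inhibition and higher numbers for more inhibition at the one concentration tested (going by the name of the read-out)), and so sits lowest of the three measured compounds. Compound 1 `CCCCCCCCCCc1ccc(-c2noc(CCCNC)n2)cc1` gives 45% in this assay, and compound 2 `CCCCCCCCCCc1ccc(-c2noc(CC3CNC3)n2)cc1` gives 63%. The measured steps were a number 24 percentage points lower from compound 1 to compound 3 (beyond the scatter) and a number 42 percentage points lower from compound 2 to compound 3 (beyond the scatter), while between the other two it was a number 18 percentage points higher from compound 1 to compound 2 (beyond the scatter). Compound 4 `CCCCCCCCCCc1ccc(-c2noc([C@H]3CCC[C@@H](N)C3)n2)cc1` carries the change (3-aminocyclohexyl in place of pyrrolidin-2-yl on an aromatic carbon). For the measured compounds named here, both steps that end at compound 3 bear on this, since in each the pyrrolidin-2-yl was the lower partner, by a modest and a large margin; no measured step contains 3-aminocyclohexyl itself. A modest step upward is therefore expected, a number 19 percentage points higher from compound 3 to compound 4 (beyond the scatter). Compound 4 is estimated at 40%, within a range from 15% to 65%.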

Compound 4, a percentage reported as inhibition, at one concentration (the size of the read-out at that concentration, not a potency): 29%
Compound 4: middle estimate off by 11 percentage points, on the high side; measured number inside the range.
By their numbers in this assay, from the lowest: compounds 3 and 4 (each within the scatter of the next); then compound 1; then compound 2.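

In this assay the change gave a number 8 percentage points higher from compound 3 to compound 4 (within the scatter), so 3-aminocyclohexyl and pyrrolidin-2-yl cannot be told apart at this position. Compound 4 still reads apart from the other two, with a number 34 percentage points lower from compound 2 to compound 4 (beyond the scatter) and a number 16 percentage points lower from compound 1 to compound 4 (beyond the scatter) as its steps. Across these four compounds, both rings carried directly on the aromatic carbon therefore sit under both groups that reach it through a saturated chain carbon, and no compound goes against this. No measurement on hand accounts for these differences. Open, on these data alone, is whether a (pyrrolidin-2-yl)methyl or (piperidin-4-yl)methyl group would read with compound 2, and whether a carboxylic acid in place of the amine would keep any inhibition.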